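A few compounds are considered here, and "the series" means these few. Any claim that something is new, unique, unknown or untested is made for them only; others in the source may bear on it.

Of the compounds shown here, three from this series have been measured in a functional assay on PANC-1 cells (Homo sapiens) for inhibition, read by MTT assay, with a stated time of 24 h, tested at 10 uM; on this read-out higher numbers stand for more inhibition at the one concentration tested (going by the name of the read-out) and lower numbers for less inhibition. Compound 1, with structure `CC(C)=CCC/C(C)=C/CC1Cc2c(O)cc(=O)n(CCCO)c2CC1(C)C`, gives 0% in this assay. Compound 2, with structure `CC(C)=CCC/C(C)=C/COc1cc(=O)n(CCCO)c2c1CC(CC=C(C)C)C(C)(C)C2`, gives 18.4%, the highest of the three numbers: its gap to compound 1 lies beyond the usual scatter, while its gap to compound 3 lies within it. Compound 3, with structure `CC(C)=CCC1Cc2c(OCCCNS(=O)(=O)c3ccc(Cl)cc3)cc(=O)n(CCCO)c2CC1(C)C`, gives 9.8% in this assay.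

Compound 4, with structure `CC(C)=CCC1Cc2c(OCCCNC(=O)c3cccs3)cc(=O)n(CCCO)c2CC1(C)C`, has not yet been measured. It differs from compound 2 in one place: 2-(((thiophen-2-yl)carbonyl)amino)ethyl in place of 2,6-dimethylhepta-1,5-dien-1-yl on a saturated chain carbon bound to an oxygen on an aromatic ring. Going by the values given here, no step between two measured compounds isolates this change, so its effect is open. Because compound 3 gives 9.8% in this assay, a modest downward step is expected here, and the expected step of a number 8.4 percentage points lower from compound 2 to compound 4 (within the scatter) is expected to remain within the scatter rather than beyond it. Compound 4 is therefore estimated to give 10% in this assay, with a range from 0% to 25%.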

Compound 4, a percentage reported as inhibition, at one concentration (the size of the read-out at that concentration, not a potency): 5.6%
Beside the measured number, compound 4's estimate is 4.4 percentage points above it; low and high end bracket the measured number.
By their numbers in this assay, from the lowest: compounds 1, 4, 3 and 2 (each within the scatter of the next, the first and the last beyond it).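

Going by these compounds alone, on a saturated chain carbon bound to an oxygen on an aromatic ring, 2-(((thiophen-2-yl)carbonyl)amino)ethyl in place of 2,6-dimethylhepta-1,5-dien-1-yl gives, in this assay, a number 12.8 percentage points lower from compound 2 to compound 4 (beyond the scatter), the first step at this position that can be read. On the amine nitrogen, (thiophen-2-yl)carbonyl in place of (4-chlorophenyl)sulfonyl gives a number 4.2 percentage points lower from compound 3 to compound 4 (within the scatter), so this read-out does not separate these two groups at the end of the chain. Nothing measured here accounts for either step.

From the compounds shown here alone, whether an amine, a carboxylic acid or a longer chain at this position would change the number remains open. With each compound tested at one concentration only, the compounds shown also leave their potencies open.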